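The source may hold more compounds than are shown below. What is called first, only, known or untested is meant among the compounds shown, and "the series" means these compounds.

Measured in an ADME assay on microsomes from liver (Rattus norvegicus), read by LC-MS, using NADPH, with a stated time of 30 min, tested at 1 uM; a lower number here means that less of the compound is left, a higher number that more of the compound is left:

Compound 1 `Cc1c(F)ccc2cc([C@H](C)Nc3ncnc(N)c3C#N)c(-c3ccccc3)c(=O)n12`: 90%
Compound 2 `Cc1cccc(-c2c([C@H](C)Nc3nc(N)nc(N)c3C#N)cc3ccc(F)cn3c2=O)c1`: 77%

Of these two numbers compound 2 holds the lower one; compound 1 sits above it by a gap that is beyond the usual scatter of this assay. Going by the values given here, no other measured pair shows how a single change shifts the result, so there is no measured step to lean on.

Compound 3 `Cc1cc(F)cc(-c2c([C@H](C)Nc3nc(N)nc(N)c3C#N)cc3ccc(F)cn3c2=O)c1` differs from compound 2 in one place: fluoro in place of hydrogen on an aromatic carbon. Among the compounds with values here, nothing among the measured compounds tells how this assay responds to such a change, and a single fluorine is a small addition. The step of a number 2 percentage points lower from compound 2 to compound 3 (within the scatter) is therefore expected to be small, with no direction that stands out beyond the scatter. Compound 3 is estimated to give 75%, with a likely range from 55% to 90%, close to the value of compound 2.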

Compound 3, percent of the compound remaining: 60%
The estimate for compound 3 lay 15 percentage points above the measured number; the range from low to high includes it.
By their numbers in this assay, from the lowest: compound 3; then compound 2; then compound 1.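

The swap of 3-methylphenyl to 3-fluoro-5-methylphenyl brings a number 17 percentage points lower from compound 2 to compound 3 (beyond the scatter) in this assay. Going by these compounds alone, this is the first single change that can be read in this small set, and it shows that one added fluorine atom, a single heavy atom with no ring and no charge, can move the percentage of compound remaining by more than ordinary repeat variation when placed on this aromatic carbon, meta to a methyl group. The direction at this position is toward less compound left, yet no measurement shown explains why the number falls.

On these data alone, one step at one position cannot show whether this shift belongs to fluoro itself or would follow from almost any group placed there, so the effect of a chloro group, a methoxy group or an amine on the same carbon remains open. Also open, as far as these compounds go, is whether fluoro on a different carbon of this ring, or a replacement of the methyl group by an ethyl group or a hydroxyl group, would move the number in the same direction.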